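The source may hold more compounds than are shown below. What is called first, only, known or untested is meant among the compounds shown, and "the series" means these compounds.

Working notes on the series. Compound 1 `O=C(Nc1ccc(-c2noc(-c3cccc(NS(=O)(=O)c4cccc(Cl)c4)c3)n2)c(Cl)c1)c1cccnc1`, compound 2 `Cc1ccc(S(=O)(=O)Nc2cccc(-c3nc(-c4ccc(NC(=O)c5cccnc5)cc4Cl)no3)c2)cc1` and compound 3 `O=C(Nc1ccc(Cl)cc1)Nc1cccc(-c2nc(-c3ccc(NC(=O)c4cccnc4)cc3Cl)no2)c1` share one core and differ only at the nitrogen on an aromatic ring. In a functional assay on MDA-MB-231 cells (Homo sapiens) for antiproliferative activity, read by MTT assay, with a stated time of 72 h (a higher number here means a weaker inhibitor, a lower number a stronger inhibitor), compound 1 gives only a limit, > 10000 nM. In this assay compound 2 likewise gives only a limit, > 10000 nM. In this assay compound 3 also gives only a limit, > 10000 nM. Compound 3 therefore stands nowhere on a scale: all three values sit at the limit of > 10000 nM in this assay, at which 3 of the 3 values shown sit. The steps a step that the two limits leave unreadable from compound 1 to compound 2, a step that the two limits leave unreadable from compound 1 to compound 3 and a step that the two limits leave unreadable from compound 2 to compound 3 carry no readable size, so none of them bears on a further change in a measurable way.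

Compound 4 `NS(=O)(=O)Nc1ccc(NC(=O)Nc2cccc(-c3nc(-c4ccc(NC(=O)c5cccnc5)cc4Cl)no3)c2)cc1` differs from compound 3 in one place: sulfamoylamino in place of chloro on an aromatic carbon. Within the data shown here, no measured step covers this replacement, and no measured compound departs from the limit, so there is nothing to read a direction from. The expected step is a step that the limit leaves unreadable from compound 3 to compound 4, which is taken to mean no change beyond the scatter. Compound 4 is estimated in this assay at 15000 nM, within 3000 nM to 60000 nM, with a substantial chance that only a limit is reported again.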

Compound 4, half-maximal inhibitory concentration: 8900 nM
Beside the measured number, compound 4's estimate is 1.7-fold (0.23 log units) above it; measured number inside the range.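

Sulfamoylamino in place of chloro, on an aromatic carbon para to a large group, is the only change shown that yields a number rather than a limit, so this position can bring the series onto a readable scale, which the changes at the nitrogen on an aromatic ring among the earlier compounds never did: the limit of > 10000 nM in this assay, at which 3 of the 4 values shown sit.

In this assay, the size of this change can be given only as a floor, an at least 1.1-fold lower number from compound 3 to compound 4 (0.05 log units; that floor lies within the scatter), so the data do not establish that the replacement lowers the number beyond the scatter. Any real gap may be larger than that floor, but the limit on the earlier compound leaves its size unknown.

The compounds shown leave open whether the readable value belongs to sulfamoylamino in particular or would also appear with an amine or a carboxylic acid on the same aromatic carbon. They also leave open whether sulfamoylamino would give a readable value with the arylsulfonyl groups of compound 1 and compound 2 on the nitrogen on an aromatic ring.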